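From 1-benzofuran-2-yl to 2-isopropyl-5-methylphenyl

This account rests on a few compounds, and the source may have more. Where it says the series, first, only, none or still open, it means among the compounds named here.

In an ADME assay on HEK293 cells (Homo sapiens) for cytotoxicity (a lower number here means a stronger inhibitor, a higher number a weaker inhibitor), compound 1 (`COC(=O)c1c(C)cc(OC(=O)c2c(C)cc(O)c(/C=N/NC(=O)COc3ccc(C)cc3)c2O)c(C)c1O`) gives only a limit, > 100000 nM. Compound 2 (`COC(=O)c1c(C)cc(OC(=O)c2c(C)cc(O)c(/C=N/NC(=O)COc3ccc(Br)cc3)c2O)c(C)c1O`) also gives only a limit, > 100000 nM. Within the data shown here, compound 3 (`COC(=O)c1c(C)cc(OC(=O)c2c(C)cc(O)c(/C=N/NC(=O)COc3cc4ccccc4o3)c2O)c(C)c1O`) gives 84400 nM, the sole true number among the three. The picture so far is therefore mostly one of the limit of > 100000 nM in this assay, at which 2 of the 3 values shown sit.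

Compound 4 (`COC(=O)c1c(C)cc(OC(=O)c2c(C)cc(O)c(/C=N/NC(=O)COc3cc(C)ccc3C(C)C)c2O)c(C)c1O`), not yet measured, differs from compound 3 in one place: 2-isopropyl-5-methylphenyl in place of 1-benzofuran-2-yl on an oxygen on a saturated carbon. In words, 2-isopropyl-5-methylphenyl stands in place of 1-benzofuran-2-yl on an oxygen on a saturated carbon.

Compound 4 again carries a substituted phenyl on that oxygen, so the expectation rests on an at least 1.1-fold lower number from compound 1 to compound 3 (0.07 log units; that floor lies within the scatter) and on an at least 1.1-fold lower number from compound 2 to compound 3 (0.07 log units; that floor lies within the scatter). Both are floors only, and neither reaches beyond the scatter. Between the two phenyl compounds there is a step that the two limits leave unreadable from compound 1 to compound 2, which adds nothing on size. No step beyond the scatter is therefore expected in this assay, at most a slightly higher number, and the assay may well report only a limit. The expected step is a 1.1-fold higher number from compound 3 to compound 4 (0.05 log units; within the scatter). For compound 4 the estimated value is 95000 nM, with an expected range of 50000 nM to 180000 nM.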

Compound 4, half-maximal inhibitory concentration: > 100000 nM
Compound 4: only a limit was reported (the forecaster's own chance of this, stated with the estimate: 55%); at least 1.0-fold (0.02 log units) between middle value and limit.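

In this assay, 2-isopropyl-5-methylphenyl in place of 1-benzofuran-2-yl on an oxygen on a saturated carbon gives an at least 1.1-fold higher number from compound 3 to compound 4 (0.07 log units; that floor lies within the scatter). Among these compounds, the one readable step at this position therefore stays a floor, and it does not establish that the change moves the read-out. The new result does show that a phenyl carrying both an isopropyl and a methyl group ends, like the 4-methylphenyl of compound 1 and the 4-bromophenyl of compound 2, at a limit of the assay, whereas the only true number belongs to the 1-benzofuran-2-yl of compound 3, and the steps that join two limits cannot be read: the limit of > 100000 nM in this assay, at which 3 of the 4 values shown sit.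

As far as these compounds go, the true values of compound 1, compound 2 and compound 4 remain unknown, so it stays open whether these phenyl groups differ from one another at all. Also open, from the compounds shown here alone, is whether an amine or a carboxylic acid on the ring at this oxygen would give a number in this assay that lies clearly apart from that of compound 3.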